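The source may report more compounds than this note shows. Statements on the series, on what has been measured and on what is new or still open speak of the compounds shown alone.

In a functional assay on A2780 cells (Homo sapiens) for antiproliferative activity, read by resazurin assay, with a stated time of 72 h (a lower number here means a stronger inhibitor, a higher number a weaker inhibitor), compound 1 (`CN(Cc1ccccc1Br)C(=O)c1cc2c(Cc3cccc(Cl)c3)n[nH]c2cc1O`) gives 130 nM and compound 2 (`COc1ccc(CN(C)C(=O)c2cc3c(Cc4cccc(Cl)c4)n[nH]c3cc2O)cc1`) gives 390 nM on the same core, so compound 2 holds the higher and therefore weaker of the two numbers. Compound 3 (`CN(Cc1cccc(NS(C)(=O)=O)c1)C(=O)c1cc2c(Cc3cccc(Cl)c3)n[nH]c2cc1O`) keeps that core but carries 3-(methanesulfonamido)phenyl in place of 4-methoxyphenyl on a saturated chain carbon bound to an amide-type nitrogen. Within the data shown here, the only measured step at this place is a 3.0-fold higher number from compound 1 to compound 2 (0.48 log units; beyond the scatter) and it is modest, swapping 2-bromophenyl for 4-methoxyphenyl. Among the measured compounds shown here, no measured compound carries the new group, so the data give no direction for this change. What is expected in this assay is therefore a 1.0-fold higher number from compound 2 to compound 3 (0.01 log units; within the scatter) and thus no shift beyond the scatter, though a modest move either way would not surprise. The estimate for compound 3 is 400 nM (expected range 130 nM to 1200 nM).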

Compound 3, half-maximal inhibitory concentration: 3200 nM
Beside the measured number, compound 3's estimate is 8.0-fold (0.90 log units) below it; the whole stated range lies below it.
By their numbers in this assay, from the lowest: compound 1; then compound 2; then compound 3.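

In this assay the group on a saturated chain carbon bound to an amide-type nitrogen proves able to move the number much further than the first pair showed: 3-(methanesulfonamido)phenyl gives an 8.2-fold higher number from compound 2 to compound 3 (0.91 log units; beyond the scatter) when it replaces 4-methoxyphenyl and a 25-fold higher number from compound 1 to compound 3 (1.39 log units; beyond the scatter) when it replaces 2-bromophenyl. This place therefore does not treat all substituted phenyl groups alike, and compound 3, whose group carries a hydrogen-bond donor that 4-methoxyphenyl lacks, has the highest number of the three. Nothing measured here explains the shift.

The compounds shown leave open whether the sulfonamide itself or its location on the ring sets this loss. Plain phenyl and 4-(methanesulfonamido)phenyl at this place would help separate the two, and 3-aminophenyl would test a different nitrogen group in the same location.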